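Methoxy to trifluoromethoxy at the limit of the assay

A few compounds are considered here, and "the series" means these few. Any claim that something is new, unique, unknown or untested is made for them only; others in the source may bear on it.

Compound 1 `CCOC(=O)c1c(-c2cccc(OC(F)(F)F)c2)[nH]c2cc(OC)ccc2c1=O`: > 21500 nM (a limit)
Compound 2 `CCOC(=O)c1c(-c2cccc(OC)c2)[nH]c2cc(OC(F)(F)F)ccc2c1=O`: > 21500 nM (a limit)

Both compounds were tested in an ADME assay on Raji cells (Homo sapiens) for cytotoxicity, read by luminescence, with a stated time of 72 h; a lower number here means that less compound is needed, a higher number that more compound is needed for the effect. Compound 2 gives > 21500 nM, which is a limit of the assay and not a number. Compound 1 gives > 21500 nM, which is also a limit. Compound 2 therefore has no exact value, and the only other result shown offers no number to compare it with: the limit of > 21500 nM in this assay, at which 2 of the 2 values shown sit.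

Compound 3 `CCOC(=O)c1c(-c2cccc(OC(F)(F)F)c2)[nH]c2cc(OC(F)(F)F)ccc2c1=O` has not yet been measured in this assay. It differs from compound 2 in one place: trifluoromethyl in place of methyl on an oxygen on an aromatic ring. In words, trifluoromethyl stands in place of methyl on an oxygen on an aromatic ring, a change from methoxy to trifluoromethoxy. Going by the values given here, no measured step shows what this change does, so the expectation rests on the shared limit alone. The expected step that the limit leaves unreadable from compound 2 to compound 3 is no larger than the usual scatter, with no direction favoured, and a further limit is the likeliest result. For compound 3 the estimated value is 28000 nM. The expected range for compound 3 runs from 12000 nM to 70000 nM.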

Compound 3, half-maximal effective concentration: > 21500 nM
Compound 3 was reported as a limit (the forecaster's own chance of this, stated with the estimate: 80%); the middle value is on the limit's open side.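

In this assay compound 3 gives > 21500 nM, which is a limit of the assay and not a number. No step from compound 1 or compound 2 to compound 3 can be read: the limit of > 21500 nM in this assay, at which 3 of the 3 values shown sit.

The compounds shown leave open whether trifluoromethyl in place of methyl on an oxygen on an aromatic ring changes the result in this assay at all, and what exact value any of the three compounds would give.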